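Amide aryl variation in the series

The source may report more compounds than this note shows. Statements on the series, on what has been measured and on what is new or still open speak of the compounds shown alone.

Measured so far:
compound 1, `O=C(Nc1cccc(-c2oc3cc(-c4ccc(F)cc4)ccc3c(=O)c2O)c1)c1ccc(F)cc1`, a functional assay on A549 cells (Homo sapiens) for antiproliferative activity, read by CCK-8 assay, with a stated time of 72 h; a higher number here means a weaker inhibitor, a lower number a stronger inhibitor: 6930 nM
compound 2, `COc1ccccc1C(=O)Nc1cccc(-c2oc3cc(-c4ccc(F)cc4)ccc3c(=O)c2O)c1`, this assay: 11700 nM

For the measured compounds named here, compound 2 carries the highest of the two numbers in this assay; the only measured step, a 1.7-fold higher number from compound 1 to compound 2 (0.23 log units; within the scatter), stays within the scatter, so the two amide aryl groups cannot be ranked on these data.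

Compound 3, `Cc1ccccc1C(=O)Nc1cccc(-c2oc3cc(-c4ccc(F)cc4)ccc3c(=O)c2O)c1`, differs from compound 2 in one place: methyl in place of methoxy on an aromatic carbon. Going by the values given here, the single measured step also alters the group on the carbonyl carbon, but it swaps a whole aryl group rather than one ortho substituent, and it was within the scatter. Among the compounds with values here, no measured pair compares methyl against methoxy. The expectation is therefore a step of a 1.2-fold lower number from compound 2 to compound 3 (0.09 log units; within the scatter) that stays within the scatter, with no direction claimed. For compound 3 the estimate in this assay is 9500 nM, in the range 3500 nM to 26000 nM.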

Compound 3, half-maximal inhibitory concentration: 17600 nM
Compound 3: the middle estimate sits 1.9-fold (0.27 log units) below what was measured; the range from low to high includes it.
By their numbers in this assay, from the lowest: compounds 1, 2 and 3 (each within the scatter of the next, the first and the last beyond it).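

In this assay, replacing methoxy with methyl on the aromatic carbon gives a 1.5-fold higher number from compound 2 to compound 3 (0.18 log units; within the scatter) and so does not separate these two groups at this position. For the compounds shown here, replacing the 4-fluorophenyl on the carbonyl carbon with 2-methylphenyl gives a 2.5-fold higher number from compound 1 to compound 3 (0.40 log units; beyond the scatter) and is the first step beyond the scatter, though only a modest one, so the identity of the amide aryl group can register in this assay. No available evidence accounts for this step.

The compounds shown leave open whether an amine, a carboxylic acid or a longer chain such as ethoxy in place of the methyl or methoxy would move the number beyond the scatter. The standing of 2-methoxyphenyl against 4-fluorophenyl also remains unresolved.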